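Replacing Fluoro with Trifluoromethoxy: Compound 3 to Compound 4

The source may hold more compounds than are shown below. What is called first, only, known or untested is meant among the compounds shown, and "the series" means these compounds.

Compound 1 `COc1ncc(-c2ccccc2)cc1[C@@H](c1ccccc1)[C@@](O)(CCN(C)C)c1cccc2ccccc12` gives > 50 ug/mL in a toxicity assay on Vero cells (Chlorocebus sabaeus) for cytotoxicity; a higher number here means that more compound is tolerated, a lower number that less compound is tolerated; this is a limit of the assay, not a number.
Compound 2 `COc1ncc(-c2ccccc2)cc1[C@@H](c1ccccc1)[C@@](O)(CCN(C)C)c1cccc(F)c1F` gives > 50 ug/mL in this assay, again a limit rather than a number.
Compound 3 `COc1nc(-c2ccc(F)cc2)ccc1[C@@H](c1ccccc1)[C@@](O)(CCN(C)C)c1cccc2ccccc12` gives > 50 ug/mL in this assay, also a limit and not a number.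

Compound 3 therefore stands where every measured compound stands: at the limit, as the limit of > 50 ug/mL in this assay, at which 3 of the 3 values shown sit, summarises. Within the data shown here, the single measured step between compounds that differ in one place, a step that the two limits leave unreadable from compound 1 to compound 2, cannot be read in size or direction because both of its ends are limits.

Compound 4 `COc1nc(-c2ccc(OC(F)(F)F)cc2)ccc1[C@@H](c1ccccc1)[C@@](O)(CCN(C)C)c1cccc2ccccc12` differs from compound 3 by trifluoromethoxy in place of fluoro on an aromatic carbon. Among the measured compounds shown here, no measured step touches this part of the molecule, and the one step that was measured gives no readable size. The expectation for compound 4 therefore rests only on the observation that all three measured compounds sit at the limit in this assay, and the step that the limit leaves unreadable from compound 3 to compound 4 is expected to be none beyond the scatter. Compound 4 is thus estimated at 60 ug/mL in this assay, with a range from 30 ug/mL to 120 ug/mL, and most likely the assay will again report only a limit.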

Compound 4, half-maximal cytotoxic concentration: > 50 ug/mL
Compound 4 was reported as a limit (the forecaster's own chance of this, stated with the estimate: 80%); the middle value does not contradict the limit.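

Compound 3 and compound 4 both give only a limit in this assay, not a number, so the step between them cannot be read in size or direction. The compounds shown leave open how much of each is actually tolerated, and whether any structural change alters that, as all share one reading: the limit of > 50 ug/mL in this assay, at which 4 of the 4 values shown sit.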